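A few compounds are considered here, and "the series" means these few. Any claim that something is new, unique, unknown or untested is made for them only; others in the source may bear on it.

The measured compounds:

compound 1 `Cc1cc(Cl)ccc1NC(=O)Nc1nc(Sc2c[nH]c3ccccc23)cc(N2CCN(Cc3ccccc3)CC2)n1`, in a functional assay on HepG2 cells (Homo sapiens) for inhibition, with a stated time of 72 h; on this read-out higher numbers stand for weaker inhibition and lower numbers for stronger inhibition: 11700 nM
compound 2 `COc1ccc(NC(=O)Nc2nc(Sc3c[nH]c4ccccc34)cc(N3CCCCC3)n2)cc1`, in this assay: 17100 nM
compound 3 `Cc1ccc(C)c(NC(=O)Nc2nc(Sc3c[nH]c4ccccc34)cc(N3CCCCC3)n2)c1`, in this assay: 6440 nM

Compound 2 has the highest of the three numbers. Its number and that of compound 1 sit within the scatter of each other; compound 3 shows a lower number, and that step, a 2.7-fold lower number from compound 2 to compound 3 (0.42 log units; beyond the scatter), lies beyond the scatter.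

Compound 4 `COc1ccc(NC(=O)Nc2nc(Nc3cc(OC)cc(OC)c3)cc(Sc3c[nH]c4ccccc34)n2)cc1` differs from compound 2 in one place: (3,5-dimethoxyphenyl)amino in place of piperidin-1-yl on an aromatic carbon. For the measured compounds named here, none of the measured steps touches this position. Going by the values given here, the only step measured, from compound 2 to compound 3, alters the aryl group on the urea nitrogen and leaves the piperidin-1-yl untouched, and compound 1 differs from compound 2 in two places at once, so its value gives no separate reading of the amine position. The data therefore offer no guide to the direction or size of the change, and the expectation rests on compound 2 alone. Compound 4 is estimated at 12000 nM, with a range from 2500 nM to 50000 nM. For compound 4 this corresponds to an expected step of a 1.4-fold lower number from compound 2 to compound 4 (0.15 log units; within the scatter), with no direction supported beyond the scatter.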

Compound 4, half-maximal inhibitory concentration: 17400 nM
Compound 4: the middle estimate sits 1.5-fold (0.16 log units) below what was measured; the measured number falls inside the stated range.
By their numbers in this assay, from the lowest: compounds 3, 1, 2 and 4 (each within the scatter of the next, the first and the last beyond it).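

In this assay, for the compounds shown here, (3,5-dimethoxyphenyl)amino in place of piperidin-1-yl on the aromatic carbon gives a 1.0-fold higher number from compound 2 to compound 4 (0.01 log units; within the scatter), the first reading of this position. The exchange swaps a non-aromatic ring for an aromatic one and adds a hydrogen-bond donor, yet the two groups cannot be told apart in this assay, so this position accepts both with the 4-methoxyphenyl urea in place. No evidence at hand bears on why the two groups read alike.

From the compounds shown here alone, it remains open whether a morpholine ring, a small open-chain amine such as dimethylamino, or an aniline carrying a carboxylic acid would shift the number at this position. Also open, going by these compounds, is whether (3,5-dimethoxyphenyl)amino would read the same alongside the 2,5-dimethylphenyl urea of compound 3.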